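The source may hold more compounds than are shown below. What is called first, only, known or untested is meant among the compounds shown, and "the series" means these compounds.

Measured in an ADME assay on cells (Lymphocyte, Homo sapiens) for cytotoxicity, read by MTT assay, with a stated time of 48 h; on this read-out higher numbers stand for weaker inhibition and lower numbers for stronger inhibition:

- compound 1 `COC(=O)/C(=C\c1ccc(O)cc1)Sc1ccnc2cc(Cl)ccc12` gives 33700 nM
- compound 2 `COC(=O)/C(=C\c1ccc(OC(=O)c2ccccc2OC)cc1)Sc1ccnc2cc(Cl)ccc12` gives > 100000 nM
- compound 3 `COC(=O)/C(=C\c1ccc(OC(=O)c2cc(OC)cc(OC)c2)cc1)Sc1ccnc2cc(Cl)ccc12` gives 84100 nM

Compound 2 gives > 100000 nM, which is a limit of the assay and not a number. It sits at the limit of > 100000 nM in this assay, at which 1 of the 3 values shown sits. Compound 4 `COC(=O)/C(=C\c1ccc(OC(=O)c2ccc(OC)cc2OC)cc1)Sc1ccnc2cc(Cl)ccc12` differs from compound 2 by methoxy in place of hydrogen on an aromatic carbon, with methoxy in place of hydrogen on an aromatic carbon, meta to a methoxy group and para to a large group.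

Two measured steps show what the acyl groups do: an at least 2.9-fold higher number from compound 1 to compound 2 (0.47 log units; beyond the scatter) and a 2.5-fold higher number from compound 1 to compound 3 (0.40 log units; beyond the scatter). Both go to higher numbers, and both are modest. The step closest to this change is an at least 1.1-fold lower number from compound 2 to compound 3 (0.07 log units; that floor lies within the scatter), where the methoxy pattern on the same ring differs. It does not go beyond the scatter. On the strength of that step, no change beyond the scatter is expected in this assay, and compound 4 should stay near the top of the range. The expected step is a number no higher from compound 2 to compound 4 (the limit leaves the size open). For compound 4 the estimated value is 100000 nM, with an expected range from 50000 nM to 200000 nM.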

Compound 4, half-maximal inhibitory concentration: 41600 nM
The estimate for compound 4 lay 2.4-fold (0.38 log units) above the measured number; measured number below the stated range.
By their numbers in this assay, from the lowest: compounds 1 and 4 (each within the scatter of the next); then compound 3. At a limit, above all of these: compound 2.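

In this assay, methoxy in place of hydrogen on this aromatic carbon, para to a large group, gives a step beyond the scatter, unlike the earlier change on the same ring, an at least 2.4-fold lower number from compound 2 to compound 4 (0.38 log units; beyond the scatter), and the 2,4-dimethoxyphenyl pattern also parts from the 3,5-dimethoxyphenyl pattern, a 2.0-fold lower number from compound 3 to compound 4 (0.31 log units; beyond the scatter). The (2,4-dimethoxyphenyl)carbonyl group is the only acyl group shown that gives no step beyond the scatter from the hydrogen it replaces, a 1.2-fold higher number from compound 1 to compound 4 (0.09 log units; within the scatter). Compound 2 stands at a limit of the assay and not at a number, so the first of these steps gives only a floor: the limit of > 100000 nM in this assay, at which 1 of the 4 values shown sits.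

As far as these compounds go, whether methoxy at this place would give the same step without the methoxy group it is meta to remains open, as does the outcome with an amine, a hydroxyl or an ethoxy group there. The compounds shown also do not tell what lies behind these steps.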